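Chloro for fluoro in the dimethyl-bearing pair

A few compounds are considered here, and "the series" means these few. Any claim that something is new, unique, unknown or untested is made for them only; others in the source may bear on it.

Measured so far in an ADME assay on cells (Hepatocyte, Canis lupus familiaris) for metabolic stability, using equilibrium dialysis; on this read-out lower numbers stand for slow clearance and higher numbers for fast clearance:
compound 1 `CC(=O)N[C@@H]1CCC[C@H](C(=O)Nc2cc(-c3cnn4c3CCCC4)c(Cl)cn2)C1` gives 14 uL/min
compound 2 `CC(=O)N[C@@H]1CCC[C@H](C(=O)Nc2cc(-c3cnn4c3CC(C)(C)C4)c(F)cn2)C1` gives 23 uL/min

Compound 2 has the higher of the two numbers, but its gap to compound 1 lies within the scatter, so the two stand level. Compound 3 `CC(=O)N[C@@H]1CCC[C@H](C(=O)Nc2cc(-c3cnn4c3CC(C)(C)C4)c(Cl)cn2)C1` is not yet measured. It differs from compound 2 in one place: chloro in place of fluoro on an aromatic carbon. Within the data shown here, compound 1 carries the same chloro and gives 14 uL/min, and no step between the measured compounds isolates this change, so the expected step in this assay is none beyond the scatter. Compound 3 is estimated at 22 uL/min, expected between 12 uL/min and 40 uL/min, a step of a 1.0-fold lower number from compound 2 to compound 3 (0.02 log units; within the scatter).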

Compound 3, intrinsic clearance in a liver preparation (reported as CLH), per the amount of preparation that the assay uses: 11 uL/min
Compound 3: middle estimate off by 2.0-fold (0.30 log units), on the high side, and the stated range ends above it.
By their numbers in this assay, from the lowest: compounds 3, 1 and 2 (each within the scatter of the next, the first and the last beyond it).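

In this assay, among these compounds, chloro in place of fluoro on this aromatic carbon gives a 2.1-fold lower number from compound 2 to compound 3 (0.32 log units; beyond the scatter) as a modest step, the first reading of this change alone. With chloro held in place, the swap of the group on the aromatic carbon gives a 1.3-fold lower number from compound 1 to compound 3 (0.10 log units; within the scatter) and leaves the two compounds level. Nothing on hand accounts for the halogen step.

Open remain whether this step carries over to the fluoro counterpart of compound 1, and how a nitrile or a methyl group would read at this position.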